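Imine substitution on the shared core: towards the styryl analogue

This account rests on a few compounds, and the source may have more. Where it says the series, first, only, none or still open, it means among the compounds named here.

For the measured compounds named here, compound 3 `COc1ccc(C2C(C#N)=C(/N=C/c3ccc(N(C)C)cc3)Oc3nc(Nc4ccc(S(N)(=O)=O)cc4)sc32)cc1` gives 36200 nM in a functional assay on MCF7 cells (Homo sapiens) for cytotoxicity, read by sulforhodamine B assay, with a stated time of 48 h (on this read-out lower numbers stand for stronger inhibition and higher numbers for weaker inhibition), the highest number of the three measured members. Compound 1 `COc1ccc(C2C(C#N)=C(N)Oc3nc(Nc4ccc(S(N)(=O)=O)cc4)sc32)cc1`, which carries the free amino group on the double-bonded ring carbon, gives 27500 nM in this assay; compound 2 `COc1ccc(C2C(C#N)=C(/N=C/c3cccc(Br)c3)Oc3nc(Nc4ccc(S(N)(=O)=O)cc4)sc32)cc1`, the 3-bromophenyl imine, gives 9390 nM.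

The step to compound 4 `COc1ccc(C2C(C#N)=C(/N=C/C=C/c3ccccc3)Oc3nc(Nc4ccc(S(N)(=O)=O)cc4)sc32)cc1` is 2-phenylethenyl in place of 4-(dimethylamino)phenyl on a carbon with a double bond to nitrogen. Going by the values given here, two measured steps bear on it. Building the 3-bromophenyl imine brought a 2.9-fold lower number from compound 1 to compound 2 (0.47 log units; beyond the scatter), while exchanging that aryl group for the dimethylaminophenyl gave a 3.9-fold higher number from compound 2 to compound 3 (0.59 log units; beyond the scatter); the direct comparison from the free amine to compound 3 is a 1.3-fold higher number from compound 1 to compound 3 (0.12 log units; within the scatter), within the scatter. The aryl part of the imine therefore moves the number by a modest amount in either direction, and the styryl group of compound 4 carries neither the bromine nor the dimethylamino group. The expectation for compound 4 is a number somewhere between those of compound 2 and compound 3, so a lower number than compound 3 is expected, a step of a 2.0-fold lower number from compound 3 to compound 4 (0.30 log units; within the scatter) in this assay, with a wide margin. Compound 4 is accordingly estimated at 18000 nM in this assay, in the range 7000 nM to 45000 nM.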

Compound 4, half-maximal inhibitory concentration: 28900 nM
Compound 4: middle estimate off by 1.6-fold (0.21 log units), on the low side; measured number inside the range.
By their numbers in this assay, from the lowest: compound 2; then compounds 1, 4 and 3 (each within the scatter of the next).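

In this assay the 2-phenylethenyl imine does not separate from the 4-(dimethylamino)phenyl imine (a 1.3-fold lower number from compound 3 to compound 4 (0.10 log units; within the scatter)) or from the free amine on the shared core (a 1.1-fold higher number from compound 1 to compound 4 (0.02 log units; within the scatter)), so exchanging 4-(dimethylamino)phenyl for 2-phenylethenyl on this carbon with a double bond to nitrogen leaves the reading within the scatter. Compound 2 alone stands apart from compound 4 (a 3.1-fold higher number from compound 2 to compound 4 (0.49 log units; beyond the scatter)), which means that building an imine at this place does not by itself lower the number: compound 3 and compound 4 go against such a pattern, and the 3-bromophenyl imine of compound 2 is the only case among the four compounds that supports it. Nothing measured here accounts for the separate standing of compound 2.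

From the compounds shown here alone, whether the bromine or the phenyl ring joined directly to the imine carbon sets compound 2 apart remains open, and a plain phenyl imine would bear directly on that question. Going by these compounds, how a saturated group such as cyclohexyl on the imine carbon would compare with the free amine of compound 1 also remains open.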